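Halogen swap on the fused ring: compound 3 to compound 4

The compounds below may be only part of what the source reports. "The series", "measured", "known", "first", "only" and "open" are said of these compounds alone.

Working notes on the series, read in a functional assay on U-373MG ATCC cells (Homo sapiens) for inhibition, read by MTT assay, with a stated time of 72 h; a higher number here means a weaker inhibitor, a lower number a stronger inhibitor. Compound 1 `COc1cccc(NC(=S)NC2CC(C)(C)Oc3ccc(Br)cc32)c1` gives 66000 nM in this assay, and compound 2 `COc1ccccc1NC(=S)NC1CC(C)(C)Oc2ccc(Br)cc21` gives 22000 nM. For the measured compounds named here, the only single-point step measured so far, a 3.0-fold lower number from compound 1 to compound 2 (0.48 log units; beyond the scatter), is also the only change in the set that goes beyond the scatter. Compound 3 `CC1(C)CC(NC(=S)NCc2ccccc2)c2cc(Cl)ccc2O1` gives 64000 nM in this assay; it stands second highest of the three numbers, within the scatter of compound 1 and separated from compound 2 alone by more than the scatter.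

Compound 4 `CC1(C)CC(NC(=S)NCc2ccccc2)c2cc(Br)ccc2O1` differs from compound 3 by bromo in place of chloro on an aromatic carbon. Going by the values given here, no measured step touches this position: the step from compound 1 to compound 2 alters the substituent on the amide-type nitrogen and leaves the halogen on the fused ring untouched, so it says nothing about bromo in place of chloro. Compounds 1 and 2 both carry bromo on the fused ring and compound 3 carries chloro, but they differ from compound 3 in more than one place, so their values cannot be read as a halogen effect. With nothing pointing either way, the expected step of a 1.1-fold lower number from compound 3 to compound 4 (0.03 log units; within the scatter) is none beyond the scatter. Compound 4 is therefore estimated at 60000 nM, with a range of 25000 nM to 150000 nM.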

Compound 4, half-maximal inhibitory concentration: 29000 nM
For compound 4 the middle estimate is 2.1-fold (0.32 log units) above the measured one; the range from low to high includes it.
By their numbers in this assay, from the lowest: compounds 2 and 4 (each within the scatter of the next); then compounds 3 and 1 (each within the scatter of the next).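

In this assay, the halogen position on the fused ring now has its first direct reading: bromo in place of chloro on an aromatic carbon gives a 2.2-fold lower number from compound 3 to compound 4 (0.34 log units; beyond the scatter), a modest step that shows this single-atom change can move the number beyond the scatter. With bromo held constant, the change on the amide-type nitrogen gives a 1.3-fold higher number from compound 2 to compound 4 (0.12 log units; within the scatter) for benzyl in place of 2-methoxyphenyl, whereas benzyl in place of 3-methoxyphenyl gives a 2.3-fold lower number from compound 1 to compound 4 (0.36 log units; beyond the scatter), so benzyl cannot be separated from 2-methoxyphenyl here but is separated from 3-methoxyphenyl. No measured property or other supporting data bear on the halogen step, so the result stands only as an observed difference in this assay.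

The halogen comparison rests on a single pair carrying benzyl on the amide-type nitrogen, leaving open whether chloro and bromo would differ in the same direction with 2-methoxyphenyl or 3-methoxyphenyl there. The compounds shown also leave open how fluoro, iodo, nitrile or an amine at the same aromatic carbon would compare with chloro and bromo.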